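The compounds below may be only part of what the source reports. "The series", "measured", "known", "first", "only" and "open" are said of these compounds alone.

Among the measured compounds shown here, compound 2 `COC1=CC(=O)C(=O)C(CCCCCCCCCCO)=C1OC` gives 1080 nM in an assay for inhibition of Polyunsaturated fatty acid 5-lipoxygenase (Homo sapiens), read by HPLC, with stated times of 15 min and 10 min (a higher number here means a weaker inhibitor, a lower number a stronger inhibitor), the higher of the two numbers measured so far; compound 1 `COC1=CC(=O)C(=O)C(CCCCCCCCO)=C1OC` gives 220 nM. Compound 3 `COC1=CC(=O)C(=O)C(CCCCCCCCCCCO)=C1OC` differs from compound 2 by hydroxymethyl in place of hydroxy on a saturated chain carbon, ten or more bonds along the chain from a double-bonded ring carbon. For the measured compounds named here, only one measured step bears on this, the earlier lengthening of the same chain, which was a 4.9-fold higher number from compound 1 to compound 2 (0.69 log units; beyond the scatter). A further step of the same kind is therefore expected to move the number up again, by a step of about a 2.3-fold higher number from compound 2 to compound 3 (0.36 log units; beyond the scatter). For compound 3 the expected value is 2500 nM, with a range from 900 nM to 7000 nM.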

Compound 3, half-maximal inhibitory concentration: 1960 nM
Compound 3: the middle estimate sits 1.3-fold (0.11 log units) above what was measured, within the range that was stated.
By their numbers in this assay, from the lowest: compound 1; then compounds 2 and 3 (each within the scatter of the next).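

In this assay, lengthening the chain once more gives a 1.8-fold higher number from compound 2 to compound 3 (0.26 log units; within the scatter), so at this chain length one further carbon makes no clear difference, unlike the earlier lengthening. Taken as a whole, the change gives an 8.9-fold higher number from compound 1 to compound 3 (0.95 log units; beyond the scatter), which leaves compound 1 clearly apart from the two longer-chain compounds. Nothing measured here explains this dependence on chain length.

Still open, going by these compounds, is how a shorter chain or a still longer chain would read. The compounds also leave open whether an amine or a carboxylic acid could replace the hydroxy group.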